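A thiophen-2-yl swap on compound 2

The source may hold more compounds than are shown below. What is called first, only, known or untested is meant among the compounds shown, and "the series" means these compounds.

Compound 1 `N[C@H]1CC[C@H](Nc2c(C(=O)NCc3ccccn3)nc(Br)c3cccnc23)CC1`: > 20000 nM (a limit of the assay)
Compound 2 `N[C@H]1CC[C@H](Nc2c(C(=O)NCc3cccc(C(F)(F)F)c3)nc(Br)c3cccnc23)CC1`: 12000 nM

Among the measured compounds shown here, in a functional assay on HEY cells (Homo sapiens) for cytotoxicity, read by MTT assay, with a stated time of 72 h (on this read-out higher numbers stand for weaker inhibition and lower numbers for stronger inhibition), compound 2 gives 12000 nM as the only exact number so far. Compound 1 gives only a limit, > 20000 nM, and no number.

Compound 3 `N[C@H]1CC[C@H](Nc2c(C(=O)NCc3cccs3)nc(Br)c3cccnc23)CC1` has not yet been measured. Its difference from compound 2 is thiophen-2-yl in place of 3-(trifluoromethyl)phenyl on a saturated chain carbon bound to an amide-type nitrogen.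

For the measured compounds named here, one measured step bears on this place: an at least 1.6-fold lower number from compound 1 to compound 2 (0.22 log units; that floor lies within the scatter). It gives only a floor within the scatter, so no step beyond the scatter is expected in this assay for this change. The expected step is a 1.2-fold higher number from compound 2 to compound 3 (0.07 log units; within the scatter) and remains small. Compound 3 is estimated at 14000 nM, with 7000 nM to 25000 nM as its expected range.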

Compound 3, half-maximal inhibitory concentration: 11000 nM
Beside the measured number, compound 3's estimate is 1.3-fold (0.10 log units) above it; low and high end bracket the measured number.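

In this assay, thiophen-2-yl in place of 3-(trifluoromethyl)phenyl on a saturated chain carbon bound to an amide-type nitrogen gives a 1.1-fold lower number from compound 2 to compound 3 (0.04 log units; within the scatter). Among the compounds shown here, this is the first step at this place that can be read between two exact numbers, and it shows that a five-membered aromatic ring with 1 hetero atom and a six-membered aromatic ring of carbon only are not told apart here. Against the pyridin-2-yl of compound 1, the comparison remains a floor, an at least 1.8-fold lower number from compound 1 to compound 3 (0.25 log units; that floor lies within the scatter), because compound 1 gives only a limit: the limit of > 20000 nM in this assay, at which 1 of the 3 values shown sits.

On these data alone, whether pyridin-2-yl truly differs from the other two groups stays open. So does whether a carboxylic acid, an amine or a longer chain at this place would move the number beyond the scatter.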